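The source may hold more compounds than are shown below. What is called first, only, known or untested is meant among the compounds shown, and "the series" means these compounds.

Compound 1, `FC(F)(F)c1ccc(CSc2nc(Nc3ccccc3Cl)c3ccccc3n2)cc1`: in a functional assay on MCF7 cells (Homo sapiens) for cytotoxicity, read by MTT assay, with a stated time of 72 h (on this read-out higher numbers stand for weaker inhibition and lower numbers for stronger inhibition), compound 1 gives > 50000 nM, a limit of the assay rather than a number.
Compound 2, `FC(F)(F)c1ccc(CSc2nc(Nc3cccc(Cl)c3)c3ccccc3n2)cc1`: in this assay compound 2 gives 25100 nM.
Compound 3, `O=[N+]([O-])c1cccc(Nc2nc(SCc3ccc(C(F)(F)F)cc3)nc3ccccc23)c1`: in this assay compound 3 gives > 50000 nM, again a limit of the assay.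

Compound 3 therefore stands at the limit of > 50000 nM in this assay, at which 2 of the 3 values shown sit, and only compound 2 supplies a number at all. The measured steps all exchange the aryl group on the nitrogen: an at least 1.9-fold lower number from compound 1 to compound 2 (0.29 log units; that floor lies within the scatter), a step that the two limits leave unreadable from compound 1 to compound 3, and an at least 1.9-fold higher number from compound 2 to compound 3 (0.29 log units; that floor lies within the scatter). None of them is readable as beyond the scatter.

Compound 4, `COc1ccc(Nc2nc(SCc3ccc(C(F)(F)F)cc3)nc3ccccc23)c(OC)c1`, differs from compound 3 in the same position: 2,4-dimethoxyphenyl in place of 3-nitrophenyl on a nitrogen on an aromatic ring. For the measured compounds named here, the steps that bear on it, from compound 1 to compound 3 and from compound 2 to compound 3, are both capped by the limit, so no step beyond the scatter is expected in this assay, in either direction. The step from compound 3 to compound 4 is estimated as an at least 1.1-fold lower number from compound 3 to compound 4 (0.04 log units; that floor lies within the scatter). Compound 4 is thus expected to give about 45000 nM, between 15000 nM and 150000 nM, with a fair chance that only a limit is reported.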

Compound 4, half-maximal inhibitory concentration: > 50000 nM
Compound 4 ended at the assay's limit; the forecaster's own chance of this, stated with the estimate: 55%; middle value at least 1.1-fold (0.04 log units) from the limit.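

In this assay compound 4 gives > 50000 nM and this is a limit of the assay. For the compounds shown here, the 2,4-dimethoxyphenyl group, which holds only carbon and oxygen, thus joins the aryl groups on this nitrogen that yield no number; the one readable step is an at least 1.9-fold higher number from compound 2 to compound 4 (0.29 log units; that floor lies within the scatter) and the steps to compound 4 from compound 1 and from compound 3 cannot be read. The set now gathers at one end of the read-out: the limit of > 50000 nM in this assay, at which 3 of the 4 values shown sit.

On these data alone, with compound 2 alone giving a number, it stays open whether any group on this nitrogen produces a step beyond the scatter. Also open, as far as these compounds go, is how an aliphatic amine or a carboxylic acid in place of the aryl group would read.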